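Tail replacement at the amide methylene of compound 2

The source may hold more compounds than are shown below. What is called first, only, known or untested is meant among the compounds shown, and "the series" means these compounds.

Measured compounds in a functional assay on MCF7 cells (Homo sapiens) for cytotoxicity, read by MTT assay, with a stated time of 24 h, tested at 32 ug/mL; a higher number here means a stronger effect of the compound at the concentration tested, a lower number a weaker effect:
compound 1 `Cn1c(-c2ccc(NC(=O)CSc3nc4ccccc4s3)cc2)nc(-c2ccccc2)c1-c1ccccc1`, 59%
compound 2 `Cc1nnc(SCC(=O)Nc2ccc(-c3nc(-c4ccccc4)c(-c4ccccc4)n3C)cc2)s1`, 83.4%

Among the measured compounds shown here, compound 2 gives the higher of the two numbers in this assay; compound 1 is the only neighbour and lies a number 24.4 percentage points higher from compound 1 to compound 2 (beyond the scatter) away, a gap beyond the scatter. Compound 3 `CN(C)/C=C/N1CCN(CC(=O)Nc2ccc(-c3nc(-c4ccccc4)c(-c4ccccc4)n3C)cc2)CC1` keeps the shared core and the amide of compound 2 and differs only in the tail: 4-(2-(dimethylamino)ethenyl)piperazin-1-yl in place of (5-methyl-1,3,4-thiadiazol-2-yl)sulfanyl on a saturated chain carbon bound to a carbonyl carbon. For the measured compounds named here, no measured step covers this exchange. Going by the values given here, the one step available, a number 24.4 percentage points higher from compound 1 to compound 2 (beyond the scatter), shows that swapping the group on the sulfur already moves this assay by a modest amount, so a change of similar size is plausible here, but its direction cannot be read from the data, and the entering group has no precedent. The estimate for compound 3 is therefore centred below compound 2, expected at 62%, between 35% and 88%, a step of a number 21.4 percentage points lower from compound 2 to compound 3 (beyond the scatter).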

Compound 3, a percentage reported as activity, at one concentration (the size of the read-out at that concentration, not a potency): 25.8%
The estimate for compound 3 lay 36.2 percentage points above the measured number; measured number outside the range, below it.
By their numbers in this assay, from the lowest: compound 3; then compound 1; then compound 2.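

In this assay, the tail on the saturated chain carbon bound to a carbonyl carbon moves the read-out further than the exchange on the sulfur suggested: a number 57.6 percentage points lower from compound 2 to compound 3 (beyond the scatter), and a number 33.2 percentage points lower from compound 1 to compound 3 (beyond the scatter), both large. With 4-(2-(dimethylamino)ethenyl)piperazin-1-yl in this place, compound 3 gives the lowest number of the three, so neither sulfur-linked tail is matched by this non-aromatic ring tail. Nothing measured on these compounds accounts for the drop.

The sulfur, the aromatic ring and the 2-(dimethylamino)ethenyl group all change in one exchange, leaving open which of them carries the step. A plain 4-methylpiperazin-1-yl or a morpholine ring in this place would separate the ring from its ethenyl amine substituent.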